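Aryl swap on the amide carbonyl: compound 2 to compound 3

A few compounds are considered here, and "the series" means these few. Any claim that something is new, unique, unknown or untested is made for them only; others in the source may bear on it.

Within the data shown here, compound 2 `COc1ccccc1C(=O)Nc1ccc2[nH]cc(C3CCN(C)CC3)c2n1` holds the lower of the two numbers measured so far: in an assay for binding affinity to 5-hydroxytryptamine receptor 1B (Homo sapiens), read by radioligand binding (on this read-out lower numbers stand for stronger inhibition and higher numbers for weaker inhibition), compound 2 gives 750 nM, while compound 1 `CN1CCC(c2c[nH]c3ccc(NC(=O)C4CC4)nc23)CC1` gives 1700 nM. Among the measured compounds shown here, the single measured step, a 2.3-fold lower number from compound 1 to compound 2 (0.36 log units; beyond the scatter), is modest. Compound 3 `CN1CCC(c2c[nH]c3ccc(NC(=O)c4cccc(F)c4)nc23)CC1` differs from compound 2 by 3-fluorophenyl in place of 2-methoxyphenyl on a carbonyl carbon. For the measured compounds named here, no measured step concerns an exchange of one aryl for another; the one step bears only on replacing cyclopropyl with an aryl, and compound 3 keeps an aryl. The expected step is therefore a 1.1-fold higher number from compound 2 to compound 3 (0.03 log units; within the scatter), not beyond the scatter. The estimate for compound 3 is 800 nM, range 300 nM to 2500 nM.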

Compound 3, inhibition constant: 1600 nM
Beside the measured number, compound 3's estimate is 2.0-fold (0.30 log units) below it; low and high end bracket the measured number.
By their numbers in this assay, from the lowest: compound 2; then compounds 3 and 1 (each within the scatter of the next).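

Exchanging one aryl for another on the carbonyl carbon is not neutral: this assay shows a 2.1-fold higher number from compound 2 to compound 3 (0.33 log units; beyond the scatter) for 3-fluorophenyl in place of 2-methoxyphenyl. An aryl alone is not enough, as 3-fluorophenyl in place of cyclopropyl gives only a 1.1-fold lower number from compound 1 to compound 3 (0.03 log units; within the scatter) in this series, so among these three compounds the lower number goes with 2-methoxyphenyl and not with aryl groups in general. No evidence is available that accounts for this difference.

Still open, going by these compounds, is whether the methoxy group alone carries the lower number of compound 2, as the two aryl groups differ in more than one respect. Also open, on these data alone, is how a pyridyl group, a benzyl group or a longer alkyl chain on the carbonyl carbon would read.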